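The source may hold more compounds than are shown below. What is called first, only, known or untested is meant among the compounds shown, and "the series" means these compounds.

In an ADME assay on Vero cells (Chlorocebus sabaeus) for cytotoxicity, read by MTT assay, with a stated time of 72 h (a lower number here means a stronger inhibitor, a higher number a weaker inhibitor), compound 1 `O=C(Nc1nc(-c2ccccc2)cs1)c1ccc([N+](=O)[O-])o1` gives 41700 nM, and compound 2 `O=C(Nc1nc(-c2cccc(C(F)(F)F)c2)cs1)c1ccc([N+](=O)[O-])o1` gives 23900 nM. For the measured compounds named here, the only measured step is a 1.7-fold lower number from compound 1 to compound 2 (0.24 log units; within the scatter), a trifluoromethyl in place of a hydrogen on an aromatic carbon. For compound 3 `Nc1cccc(-c2csc(NC(=O)c3ccc([N+](=O)[O-])o3)n2)c1` the result in this assay is "not determined" (no result reported), so it stands without a number of its own. Compound 4 `O=C(Nc1nc(-c2cccc(NC(=O)C3CCCCC3)c2)cs1)c1ccc([N+](=O)[O-])o1` differs from compound 3 by cyclohexylcarbonyl in place of hydrogen on a nitrogen on an aromatic ring. Going by the values given here, no measured step touches that nitrogen, and the single known step lies within the scatter, with both measured values close together; no step beyond the scatter is therefore expected in this assay in either direction. Compound 4 is estimated at 30000 nM, with a range from 10000 nM to 90000 nM.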

Compound 4, half-maximal inhibitory concentration: 21900 nM
Beside the measured number, compound 4's estimate is 1.4-fold (0.14 log units) above it; the measured number falls inside the stated range.
By their numbers in this assay, from the lowest: compounds 4, 2 and 1 (each within the scatter of the next).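

In this assay, (cyclohexylcarbonyl)amino on the aromatic carbon in place of trifluoromethyl gives (a 1.1-fold lower number from compound 2 to compound 4 (0.04 log units; within the scatter)), and in place of hydrogen it gives (a 1.9-fold lower number from compound 1 to compound 4 (0.28 log units; within the scatter)). Both steps lie within the scatter, so hydrogen, trifluoromethyl and this far bulkier amide group are not told apart at this place on the aromatic ring. Nothing given here bears on why the three numbers stay together. The compounds shown leave open whether a carboxylic acid at this place, or a longer chain in place of the cyclohexyl ring, would give a step beyond the scatter.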